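The compounds below may be only part of what the source reports. "The series", "measured", "known", "first", "only" and "open" are said of these compounds alone.

Measured so far in an assay on HEK293 cells for displacement of a labelled ligand from 5-hydroxytryptamine receptor 6 (Homo sapiens); a higher number here means a weaker inhibitor, a lower number a stronger inhibitor:

compound 1 `O=C1c2ccccc2S(=O)(=O)N1CCCCCN1CCN(c2ccc(Cl)cc2)CC1`: 703 nM
compound 2 `O=C1c2ccccc2S(=O)(=O)N1CCCCCN1CCN(c2ccccc2)CC1`: 1840 nM
compound 3 `O=C1c2ccccc2S(=O)(=O)N1CCCCCN1CCN(c2cccc(C(F)(F)F)c2)CC1`: 1350 nM

All three compounds share the same core and differ only in the aromatic ring carried by the amine nitrogen of the six-membered ring. Compound 3 gives the second highest of the three numbers in this assay; its nearest neighbour is compound 2 a 1.4-fold lower number from compound 2 to compound 3 (0.13 log units; within the scatter), and its furthest is compound 1 a 1.9-fold higher number from compound 1 to compound 3 (0.28 log units; within the scatter), so compound 3 sits within the scatter of both.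

Compound 4 `O=C1c2ccccc2S(=O)(=O)N1CCCCCN1CCN(c2cccc(Cl)c2Cl)CC1` is not yet measured. It differs from compound 3 as follows: 2,3-dichlorophenyl in place of 3-(trifluoromethyl)phenyl on an amine nitrogen in a ring. The measured steps that bear on this change are the one from a chloro-bearing ring to a bare ring a 2.6-fold higher number from compound 1 to compound 2 (0.42 log units; beyond the scatter), which is modest but beyond the scatter, and the two steps involving the trifluoromethyl ring a 1.9-fold higher number from compound 1 to compound 3 (0.28 log units; within the scatter) and a 1.4-fold lower number from compound 2 to compound 3 (0.13 log units; within the scatter), both within the scatter. Compound 4 keeps chloro substitution, so a step downward in this assay of small size is expected, a 1.5-fold lower number from compound 3 to compound 4 (0.18 log units; within the scatter), likely close to the scatter. For compound 4 the estimate in this assay is 900 nM, with a range from 350 nM to 2500 nM.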

Compound 4, inhibition constant: 197 nM
For compound 4 the middle estimate is 4.6-fold (0.66 log units) above the measured one, outside the stated range (below it).
By their numbers in this assay, from the lowest: compound 4; then compounds 1, 3 and 2 (each within the scatter of the next, the first and the last beyond it).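

In this assay, the aromatic ring on the amine nitrogen matters more than the first three compounds suggested: 2,3-dichlorophenyl in place of 3-(trifluoromethyl)phenyl gives a 6.9-fold lower number from compound 3 to compound 4 (0.84 log units; beyond the scatter), a larger step than any seen among those three. The same ring also outperforms the bare phenyl ring, with a 9.3-fold lower number from compound 2 to compound 4 (0.97 log units; beyond the scatter), and the 4-chlorophenyl ring, with a 3.6-fold lower number from compound 1 to compound 4 (0.55 log units; beyond the scatter), so compound 4 is the most potent of the four, and a single chloro on the ring, as in compound 1, does not account for the whole gain. Nothing measured here explains why this ring does so much better.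

The compounds shown do not tell whether both chloro groups of the 2,3-dichlorophenyl ring are needed, since the two arrive together, or whether a methoxy or fluoro group on this ring could serve as well. As far as these compounds go, it also remains open whether the gain would hold with a shorter or longer chain linking the shared core to the six-membered ring.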